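This account rests on a few compounds, and the source may have more. Where it says the series, first, only, none or still open, it means among the compounds named here.

Compound 1 `Cc1cc(C)c(CN2CCc3c(Cl)cc(C(CO)c4ccon4)c(Cl)c3C2=O)c(=O)[nH]1`: 2; 2 (2 entries) in a physicochemical assay for lipophilicity, at pH 7.4; a lower number here means a more polar compound, a higher number a more lipophilic compound
Compound 2 `Cc1cc(C)c(CN2CCc3c(Cl)cc([C@H](CO)[C@@H]4CCCO4)c(Cl)c3C2=O)c(=O)[nH]1`: 2.4

Among the measured compounds shown here, compound 2 carries the only single number and reads above both entries of compound 1. Compound 3 `Cc1cc(C)c(CN2CCc3c(Cl)cc([C@H](C)CO)c(Cl)c3C2=O)c(=O)[nH]1` differs from compound 2 as follows: a group of 4 heavy atoms (3 carbon, 1 oxygen; no ring) in place of a group of 8 heavy atoms (6 carbon, 2 oxygen; one five-membered non-aromatic ring with 1 hetero atom), on an aromatic carbon. The group of 8 heavy atoms gives way to 1-(hydroxymethyl)ethyl on an aromatic carbon. For the measured compounds named here, no measured pair isolates this change, so the expectation in this assay is anchored on compound 2 at 2.4: no shift beyond the scatter, with a faint lean downward. The estimated step is a number 0.10 log units lower from compound 2 to compound 3 (within the scatter). Compound 3 is expected at 2.3, with an estimated range of 1.9 to 2.7.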

Compound 3, distribution coefficient: 2.6
For compound 3 the middle estimate is 0.30 log units below the measured one; the measured number falls inside the stated range.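

In this assay, exchanging the group of 8 heavy atoms for 1-(hydroxymethyl)ethyl on the aromatic carbon gives a number 0.20 log units higher from compound 2 to compound 3 (within the scatter) for this single change. At this position, ortho to a chloro group, the five-membered non-aromatic ring can therefore be lost without a shift beyond the scatter in this read-out. No available evidence accounts for the step.

Still open, going by these compounds, is whether an amine or a carboxylic acid in place of the hydroxyl of 1-(hydroxymethyl)ethyl would also stay within the scatter in this assay at this position. On these data alone, the effect of inverting the defined stereocentre of compound 3 also remains open.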